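This account rests on a few compounds, and the source may have more. Where it says the series, first, only, none or still open, it means among the compounds named here.

In a functional assay (aorta) for inhibition, with Rattus norvegicus as the target (a lower number here means a stronger inhibitor, a higher number a weaker inhibitor), compound 1 `CC1(C)Oc2ccc(C#N)cc2[C@@H](/N=C(\NC#N)Nc2ccccc2)[C@@H]1O` was measured repeatedly and gives 1400 nM; 4200 nM; 1300 nM (3 entries), while compound 2 `CCC(C)(C)/N=C(\NC#N)N[C@@H]1c2cc(C#N)ccc2OC(C)(C)[C@H]1O` gives 29800 nM. Compound 3 `CC1(C)Oc2ccc(C#N)cc2[C@@H](/N=C(\NC#N)Nc2ccc(O)cc2)[C@@H]1O`, at 2200 nM, has the lower of the two single readings, a gap to compound 2 that lies beyond the scatter, and its value falls inside the range of the entries for compound 1. Compound 4 `CC1(C)Oc2ccc(C#N)cc2[C@@H](/N=C(\NC#N)Nc2ccc(Cl)cc2)[C@@H]1O` has chloro in place of hydroxy on an aromatic carbon, para to a large group. Compound 1, which carries neither group there, reads 1400 nM; 4200 nM; 1300 nM (3 entries), close to compound 3 at 2200 nM, so no large change is expected. The expected step of a 1.4-fold lower number from compound 3 to compound 4 (0.14 log units; within the scatter) stays within the scatter. For compound 4 the estimated value is 1600 nM, with an expected range from 550 nM to 4500 nM.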

Compound 4, half-maximal inhibitory concentration: 1800 nM
For compound 4 the middle estimate is 1.1-fold (0.05 log units) below the measured one; low and high end bracket the measured number.
By their numbers in this assay, from the lowest: compounds 4 and 3 (each within the scatter of the next); then compound 2.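

With the change from 4-hydroxyphenyl to 4-chlorophenyl, this assay records a 1.2-fold lower number from compound 3 to compound 4 (0.09 log units; within the scatter), so chloro and hydroxy at this position cannot be told apart by their readings. The step is also smaller than the spread among repeated readings of a single compound: the several entries of compound 1 in this assay, 1400 nM; 4200 nM; 1300 nM (3 entries)

The compounds shown carry only hydroxy or chloro at this position, or neither group. From the compounds shown here alone, whether an amine or a carboxylic acid on this aromatic carbon, para to a large group, would move the reading beyond the scatter remains open.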